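This account rests on a few compounds, and the source may have more. Where it says the series, first, only, none or still open, it means among the compounds named here.

Measured compounds:
compound 1, `CCSc1nc(=O)ccn1[C@@H]1O[C@H](COP(=O)(O)O)[C@@H](O)[C@H]1O`: 1500 nM
compound 2, `CSc1nc(=O)ccn1[C@@H]1O[C@H](COP(=O)(O)O)[C@@H](O)[C@H]1O`: 2900 nM
compound 3, `COc1nc(=O)ccn1[C@@H]1O[C@H](COP(=O)(O)O)[C@@H](O)[C@H]1O`: 9900 nM

Compound 3 stands at the highest number of the three in an in vitro functional assay on 1321-N1 cells for agonist activity at P2Y purinoceptor 2 (Homo sapiens), read by scintillation proximity assay and inositol phosphate accumulation; on this read-out higher numbers stand for an effect only at larger amounts of compound and lower numbers for an effect already at smaller amounts; its nearest neighbour is compound 2, the step being a 3.4-fold higher number from compound 2 to compound 3 (0.53 log units; beyond the scatter), and the furthest is compound 1, the step being a 6.6-fold higher number from compound 1 to compound 3 (0.82 log units; beyond the scatter). Compound 4 is `CCCSc1nc(=O)ccn1[C@@H]1O[C@H](COP(=O)(O)O)[C@@H](O)[C@H]1O`; its change from compound 3 is propylsulfanyl in place of methoxy on an aromatic carbon. For the measured compounds named here, two measured steps bear on this directly: the exchange of methoxy for a sulfanyl group is covered by a 3.4-fold higher number from compound 2 to compound 3 (0.53 log units; beyond the scatter) and by a 6.6-fold higher number from compound 1 to compound 3 (0.82 log units; beyond the scatter), both read in reverse here, so a move from methoxy to a sulfanyl chain has given a lower number each time. Lengthening of the chain on the sulfur, a 1.9-fold higher number from compound 1 to compound 2 (0.29 log units; within the scatter) read in reverse, adds at most a small shift that stays within the scatter. The number expected for compound 4 is therefore lower, by a step of about the size seen for the sulfanyl compounds or slightly larger: an 8.3-fold lower number from compound 3 to compound 4 (0.92 log units; beyond the scatter). Compound 4 is estimated to give 1200 nM in this assay, with a likely range from 400 nM to 4000 nM.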

Compound 4, half-maximal effective concentration: 4800 nM
For compound 4 the middle estimate is 4.0-fold (0.60 log units) below the measured one; the measured number lies above the stated range.
By their numbers in this assay, from the lowest: compounds 1, 2 and 4 (each within the scatter of the next, the first and the last beyond it); then compound 3.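

In this assay, propylsulfanyl on the aromatic carbon between two ring nitrogen atoms keeps a lower number than methoxy (a 2.1-fold lower number from compound 3 to compound 4 (0.31 log units; beyond the scatter)), so all three sulfanyl chains shown lie on the same side of methoxy at this position. Lengthening the chain on the sulfur does not, however, keep lowering the number: going from ethylsulfanyl to propylsulfanyl raises it beyond the scatter (a 3.2-fold higher number from compound 1 to compound 4 (0.51 log units; beyond the scatter)), while the methylsulfanyl and propylsulfanyl compounds stay within the scatter of each other (a 1.7-fold higher number from compound 2 to compound 4 (0.22 log units; within the scatter)), so the series shows no steady trend with chain length. No supporting measurement bears on these steps, and the numbers alone offer no explanation for them.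

Still open, as far as these compounds go, is whether the sulfur or the chain length decides the outcome, since ethoxy and propoxy would pair directly with compound 1 and compound 4 and differ from them in one place only. Also open is how a butylsulfanyl chain, a branched isopropylsulfanyl group, a benzylsulfanyl group or an amine on the same carbon would compare with the sulfanyl chains and methoxy shown here.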